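Methyl in Place of Diethylamino: Expected Effect on Potency

The compounds below may be only part of what the source reports. "The series", "measured", "known", "first", "only" and "open" are said of these compounds alone.

Compound 1 `CCN(CC)c1ccc(N2C(=O)NC3(CSC4=C3C(=O)c3ncccc3C4=O)C2=O)cc1`: 50 nM
Compound 2 `O=C1NN(c2ccc(Cl)cc2)C(=O)C2(CSC3=C2C(=O)c2ncccc2C3=O)N1`: 150 nM

Of the compounds shown here, two have been tested in a functional assay on HeLa cells (Homo sapiens) for antiproliferative activity, read by MTT assay, with a stated time of 96 h; a lower number here means a stronger inhibitor, a higher number a weaker inhibitor. Compound 1 gives 50 nM, the lowest of the two numbers. Compound 2 gives 150 nM, a higher number, and the gap lies beyond the usual scatter. Compound 3 `Cc1ccc(N2C(=O)NC3(CSC4=C3C(=O)c3ncccc3C4=O)C2=O)cc1` has not yet been measured. It differs from compound 1 in one place: methyl in place of diethylamino on an aromatic carbon. Among the measured compounds shown here, no measured pair shows the effect of this change, so the direction is uncertain. A modest weakening, near the edge of the scatter, is expected: a 2.0-fold higher number from compound 1 to compound 3 (0.30 log units; within the scatter). Compound 3 is therefore estimated at 100 nM, in a range from 30 nM to 400 nM.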

Compound 3, half-maximal inhibitory concentration: 2 nM
Beside the measured number, compound 3's estimate is 50-fold (1.70 log units) above it; the measured number lies below the stated range.
By their numbers in this assay, from the lowest: compound 3; then compound 1; then compound 2.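

In this assay, putting methyl in place of diethylamino on this aromatic carbon gives a 25-fold lower number from compound 1 to compound 3 (1.40 log units; beyond the scatter), a large step beyond the scatter. This position is therefore highly sensitive to the group it carries, and diethylamino is not needed here for strong activity. No evidence at hand explains why the change has this effect. From the compounds shown here alone, what a bare hydrogen, an ethyl or a methoxy would give at this place remains open. The compounds shown therefore cannot tell whether potency simply follows the size of the group.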